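A few compounds are considered here, and "the series" means these few. Any claim that something is new, unique, unknown or untested is made for them only; others in the source may bear on it.

Measured so far in a functional assay on HCT-8 cells (Homo sapiens) for antiproliferative activity, read by MTT assay, with a stated time of 48 h; on this read-out lower numbers stand for stronger inhibition and higher numbers for weaker inhibition:
- compound 1 `COc1ccc(C(=O)c2ccc(OC)c3c2C=CC(C)(C)O3)c(NC(=O)CBr)c1`: 4360 nM
- compound 2 `COc1ccc(C(=O)c2ccc3c(c2)C=CC(C)(C)O3)c(NC(=O)CBr)c1`: 3260 nM
- compound 3 `COc1ccc(C(=O)c2ccc(OC)c3c2C=CC(C)(C)O3)c(NC(=O)CO)c1`: 630 nM

Compound 2 at 3260 nM lies within the scatter of compound 1 at 4360 nM. Compound 3 at 630 nM gives the lowest number, beyond the scatter from both.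

The next compound is compound 4 `COc1ccc(C(=O)c2ccc3c(c2)C=CC(C)(C)O3)c(NC(=O)CN)c1`, which differs from compound 2 as follows: amino in place of bromo on a saturated chain carbon bound to a carbonyl carbon. Going by the values given here, no measured step has an amino group entering. The closest evidence is a modest step at the same place, a 6.9-fold lower number from compound 1 to compound 3 (0.84 log units; beyond the scatter), where hydroxy replaces bromo. That step was measured on the core of compound 1, not on that of compound 2, and hydroxy is not amino, so it serves only as a guide to direction and rough size. A lower number in this assay is therefore expected, with a step somewhat smaller than that guide.

The expected step is a 4.7-fold lower number from compound 2 to compound 4 (0.67 log units; beyond the scatter).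

For compound 4 the estimate is 700 nM, with an expected range from 200 nM to 2400 nM.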

Compound 4, half-maximal inhibitory concentration: 490 nM
Estimate against measurement, compound 4: 1.4-fold (0.15 log units) above; the measured number falls inside the stated range.
By their numbers in this assay, from the lowest: compounds 4 and 3 (each within the scatter of the next); then compounds 2 and 1 (each within the scatter of the next).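

In this assay, amino in place of bromo on a saturated chain carbon bound to a carbonyl carbon gives a 6.7-fold lower number from compound 2 to compound 4 (0.82 log units; beyond the scatter), so a lower number at this place is no longer tied to hydroxy or to the core of compound 1. Alongside a 6.9-fold lower number from compound 1 to compound 3 (0.84 log units; beyond the scatter), the series now holds two different replacements of bromo at this place, on two different cores, and both steps point the same way. No measurement shown gives a cause for either step.

The compounds shown leave open how a dimethylamino group, a carboxylic acid or a longer chain such as aminoethyl would read at this place. Also open, as far as these compounds go, is whether amino and hydroxy each keep the size of their step on the other core.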